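This account rests on a few compounds, and the source may have more. Where it says the series, first, only, none or still open, it means among the compounds named here.

Compound 1 `Cc1cc(C)c(NC(=O)N(Cc2cccc(-c3cc[nH]n3)c2)C2CCCCC2)c(C)c1` carries a cyclohexyl on the amide-type nitrogen; in a functional assay on a cell-free system (plasma) with sterol O-acyltransferase, Soat (Rattus norvegicus) as the target (a lower number here means that less compound is needed, a higher number that more compound is needed for the effect), compound 1 gives 0.12 mg/kg. Compound 2 `Cc1cc(C)c(NC(=O)N(Cc2cccc(-c3cc[nH]n3)c2)C2CCCC2)c(C)c1` carries cyclopentyl in its place. In this assay compound 2 gives < 1 mg/kg, which is a limit of the assay and not a number. The step that the limit leaves unreadable from compound 1 to compound 2 is thus not readable in size, and compound 2 stands only at the limit of < 1 mg/kg in this assay, at which 1 of the 2 values shown sits. Compound 3 `Cc1cc(C)c(NC(=O)N(Cc2ccccc2)Cc2cccc(-c3cc[nH]n3)c2)c(C)c1` differs from compound 2 by benzyl in place of cyclopentyl on an amide-type nitrogen. Going by the values given here, no measured step bears on this change, so no direction beyond the scatter is set. Compound 3 is expected at 0.3 mg/kg (range 0.06 mg/kg to 1.5 mg/kg), an estimated step that the limit leaves unreadable from compound 2 to compound 3.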

Compound 3, dose for half-maximal effect: > 1 mg/kg
Compound 3: a limit, no number; the forecaster's own chance of this, stated with the estimate: 40%; middle value at least 3.3-fold (0.52 log units) away from the limit.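

In this assay compound 3 gives > 1 mg/kg, which is a limit of the assay and not a number. Against cyclohexyl, benzyl on the amide-type nitrogen gives an at least 8.3-fold higher number from compound 1 to compound 3 (0.92 log units; beyond the scatter), the first step at this place that can be read in size. Against cyclopentyl, benzyl on the amide-type nitrogen gives a number no lower from compound 2 to compound 3 (the limit leaves the size open). The steps involving compound 2 cannot be read in size.

From the compounds shown here alone, how far compound 3 actually lies from compound 1 remains open, as does the true position of compound 2. Also open, going by these compounds, is how a straight hexyl chain or a piperidine ring would read on this nitrogen.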